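The source may report more compounds than this note shows. Statements on the series, on what has been measured and on what is new or still open speak of the compounds shown alone.

Measured compounds:
- compound 1, `O=C(CCCSC[C@H](NC(=O)OCc1ccccc1)C(=O)Nc1ccccc1)NCc1ccccc1`: 30%
- compound 2, `CCCCCCCCNC(=O)CCCSC[C@H](NC(=O)OCc1ccccc1)C(=O)Nc1ccccc1`: "not active" (no number reported)
- compound 3, `NC(=O)CCCSC[C@H](NC(=O)OCc1ccccc1)C(=O)Nc1ccccc1`: 11%

In an assay for inhibition of NAD-dependent protein deacylase sirtuin-6 (Homo sapiens), read by HPLC, with stated times of 15 min and 1 h, tested at 333 uM (on this read-out lower numbers stand for less inhibition and higher numbers for more inhibition at the one concentration tested (going by the name of the read-out)), compound 3 stands lowest of the two compounds that have a number, with compound 1 the nearest, and compound 2 reported without a number. Compound 4, `CNC(=O)CCCSC[C@H](NC(=O)OCc1ccccc1)C(=O)Nc1ccccc1`, differs from compound 3 by methyl in place of hydrogen on an amide-type nitrogen. Going by the values given here, the one measured step at this nitrogen is a number 19 percentage points lower from compound 1 to compound 3 (beyond the scatter), a modest fall when the benzyl group was removed. A single methyl is a far smaller addition than a benzyl, so only a small rise, if any, is expected in this assay, likely within the scatter. Compound 4 is therefore estimated at 16%, with a range from 5% to 28%, meaning an expected step of a number 5 percentage points higher from compound 3 to compound 4 (within the scatter).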

Compound 4, a percentage reported as inhibition, at one concentration (the size of the read-out at that concentration, not a potency): "not active" (no number reported)
The entry for compound 4 holds no number; there is nothing to compare the estimate with.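

Going by these compounds alone, compound 4 is reported as not active with no number, so no step from compound 3 to compound 4 can be read. From the compounds shown here alone, how far methyl on the amide-type nitrogen shifts inhibition stays open, and no evidence here bears on this result.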